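Trifluoromethyl in Place of Methyl on an Aryl Ether

The compounds below may be only part of what the source reports. "The series", "measured", "known", "first", "only" and "open" are said of these compounds alone.

Of the compounds shown here, two built on the same core have been measured. Compound 1 `Nc1scc(CN2CCN(c3cccc(Cl)c3Cl)CC2)c1C(=O)c1ccc(Cl)cc1` and compound 2 `COc1ccc(N2CCN(Cc3csc(N)c3C(=O)c3ccc(Cl)cc3)CC2)cc1` were both examined in an assay on CHO cells for displacement of a labelled ligand from adenosine receptor A3 (Homo sapiens), read by scintillation counting, with a stated time of 120 min, tested at 10 uM; on this read-out lower numbers stand for less inhibition and higher numbers for more inhibition at the one concentration tested (going by the name of the read-out). In this assay compound 1 gives 0%; in the same this assay compound 2 gives 0%. For the measured compounds named here, the one measured step, no change at the digits printed from compound 1 to compound 2 (within the scatter), exchanges 4-methoxyphenyl for 2,3-dichlorophenyl on an amine nitrogen in a ring and leaves the read-out where it was. Compound 2 therefore stands level with compound 1 at the digits shown, with no inhibition recorded for either.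

Compound 3 `Nc1scc(CN2CCN(c3ccc(OC(F)(F)F)cc3)CC2)c1C(=O)c1ccc(Cl)cc1` differs from compound 2 by trifluoromethyl in place of methyl on an oxygen on an aromatic ring, that is, methoxy becomes trifluoromethoxy and 4-methoxyphenyl becomes 4-(trifluoromethoxy)phenyl. Going by the values given here, no measured step touches this oxygen. Among the compounds with values here, the only step available, from compound 1 to compound 2, altered the whole aryl group and produced no change, so a smaller alteration on that same aryl group is expected to move the read-out no further. The expected step of a number 2 percentage points higher from compound 2 to compound 3 (within the scatter) is none beyond the scatter. Compound 3 is expected to give 2%, between 0% and 15%.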

Compound 3, a percentage reported as inhibition, at one concentration (the size of the read-out at that concentration, not a potency): 1%
The estimate for compound 3 lay 1 percentage points above the measured number, within the range that was stated.
By their numbers in this assay, from the lowest: compounds 1, 2 and 3 (each within the scatter of the next).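

In this assay, trifluoromethyl on an oxygen on an aromatic ring, where methyl stood before, gives a number 1 percentage points higher from compound 2 to compound 3 (within the scatter), so this oxygen substituent now has a direct reading that the earlier pair did not provide, and the exchange of one heavy atom for four does not take the number beyond the scatter. Across the amine nitrogen in a ring, 4-(trifluoromethoxy)phenyl in place of 2,3-dichlorophenyl gives a number 1 percentage points higher from compound 1 to compound 3 (within the scatter), so three different aryl groups at this nitrogen now read alike at the one concentration tested. No available evidence bears on why these numbers lie so close together.

The compounds shown leave open whether a carboxylic acid or an amine on that aromatic ring, or a longer chain such as propyl on the oxygen, would give a number beyond the scatter. They also leave open whether a change elsewhere on the shared core, such as replacing the free amine or the carbonyl, would lift the number in this assay with any of these aryl groups in place.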